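Removing methylamino from two related cores

The compounds below may be only part of what the source reports. "The series", "measured", "known", "first", "only" and "open" are said of these compounds alone.

Compound 1 `CNc1nc(N2CCN(C)CC2)nc2ccccc12` gives 2.95 nM in an assay on HEK293 cells for displacement of a labelled ligand from 5-hydroxytryptamine receptor 3A (Homo sapiens), read by scintillation counting, with a stated time of 24 h, in the presence of a further agent that is not named here; on this read-out lower numbers stand for stronger inhibition and higher numbers for weaker inhibition. Compound 3 `CN1CCN(c2ncc3ccccc3n2)CC1` shares its core but carries a hydrogen where compound 1 carries methylamino; in this assay compound 3 gives 1.35 nM. The change hydrogen in place of methylamino on an aromatic carbon brings the step of a 2.2-fold lower number from compound 1 to compound 3 (0.34 log units; beyond the scatter). Compound 2 `CNc1nc(N2CCN(C)CC2)cc2ccccc12` is built on another core; how the two cores differ is not broken down here. In this assay compound 2 gives 5.89 nM, a number that lies within the scatter of compound 1 and clearly above that of compound 3. Compound 4 `CN1CCN(c2cc3ccccc3cn2)CC1` stands to compound 2 as compound 3 stands to compound 1: hydrogen in place of methylamino on an aromatic carbon. The surroundings are not the same word for word: on the core of compound 1 the ring holds 2 nitrogen and the carbon is opposite the ring nitrogen, on the core of compound 2 the ring holds 1 nitrogen, so this is the same kind of change rather than the same one. Because a 2.2-fold lower number from compound 1 to compound 3 (0.34 log units; beyond the scatter) was seen on the other core, a step of similar size is expected here, namely a 2.1-fold lower number from compound 2 to compound 4 (0.32 log units; beyond the scatter). Compound 4 is accordingly estimated at 2.8 nM, with a likely range from 1.4 nM to 5.9 nM.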

Compound 4, inhibition constant: 1.62 nM
For compound 4 the middle estimate is 1.7-fold (0.24 log units) above the measured one, and the stated range covers the measured number.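

Replacing methylamino with hydrogen on an aromatic carbon gives a lower number on both cores, with a 3.6-fold lower number from compound 2 to compound 4 (0.56 log units; beyond the scatter) on the second, and the two steps do not separate: the same change on two cores in this assay, a 2.2-fold lower number (0.34 log units; beyond the scatter) from compound 1 to compound 3 and a 3.6-fold lower number (0.56 log units; beyond the scatter) from compound 2 to compound 4, 1.7-fold (0.22 log units) apart, within the scatter of two such steps. In this assay, the change therefore carries from the core of compound 1 to the core of compound 2 in direction and, within the scatter, in size, so the larger step on the second core should not be read as a real difference. Among the compounds shown here, this rests on only two matched pairs, so it does not establish a rule for other cores, and it does not explain why removing methylamino goes with a lower number.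

Still open, going by these compounds, is where other groups on the same aromatic carbon, such as an unsubstituted amine, dimethylamino, methoxy or a longer chain such as ethylamino, would fall relative to hydrogen and methylamino. Also open, on these data alone, is whether the step would hold on a third core.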